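Replacing the Side Group on the Shared Core

This account rests on a few compounds, and the source may have more. Where it says the series, first, only, none or still open, it means among the compounds named here.

Compound 2 `CCC(=O)NC[C@H]1CN(c2ccc(-n3cc(-c4ccccn4)cn3)c(F)c2)C(=O)O1` and compound 1 `O=C1O[C@@H](Cn2ccnc2)CN1c1ccc(-n2cc(-c3ccccn3)cn2)c(F)c1` share one core and differ only in a group on a saturated chain carbon. In an ADME assay on L02 cells (Homo sapiens) for cytotoxicity, read by MTT assay, with a stated time of 48 h (a higher number here means a weaker inhibitor, a lower number a stronger inhibitor), compound 1 gives 350 ug/mL and compound 2 gives 204 ug/mL; the step of a 1.7-fold lower number from compound 1 to compound 2 (0.23 log units; within the scatter) leaves the two compounds within the scatter of each other, so neither stands apart. Going by the values given here, compound 3 `CONC(=O)[C@H]1CN(c2ccc(-n3cc(-c4ccccn4)cn3)c(F)c2)C(=O)O1` changes compound 2 at a different place: methoxycarbamoyl in place of (propanoylamino)methyl on a saturated ring carbon The only measured step swaps the group at the end of a chain rather than the group sitting directly on the ring carbon, so it does not bear closely on this change, and it stayed within the scatter anyway. Nothing here argues for a shift beyond the scatter in either direction, so compound 3 is expected to give a number close to that of compound 2, as the expected step of a 1.1-fold higher number from compound 2 to compound 3 (0.03 log units; within the scatter) states. The estimate for compound 3 is 220 ug/mL, with a range from 110 ug/mL to 450 ug/mL.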

Compound 3, half-maximal inhibitory concentration: > 400 ug/mL
Compound 3: only a limit was reported; the forecaster's own chance of this, stated with the estimate: 10%; middle value at least 1.8-fold (0.25 log units) away from the limit.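

In this assay compound 3 gives > 400 ug/mL, which is a limit of the assay and not a number. Placing methoxycarbamoyl on the saturated ring carbon next to the ring oxygen gives an at least 1.9-fold higher number from compound 2 to compound 3 (0.29 log units; that floor lies within the scatter) and an at least 1.1-fold higher number from compound 1 to compound 3 (0.05 log units; that floor lies within the scatter), so this new group at this place shows no sign of a lower number, although both floors lie within the scatter. The true size of the two steps cannot be read, because compound 3 sits at a limit: the limit of > 400 ug/mL in this assay, at which 1 of the 3 values shown sits.

As far as these compounds go, how far the number of compound 3 lies past that limit stays open. Also open, from the compounds shown here alone, is whether a carboxylic acid, an amine or a longer chain on the same ring carbon would give a number as high.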